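This account rests on a few compounds, and the source may have more. Where it says the series, first, only, none or still open, it means among the compounds named here.

In a functional assay on MKN-45 cells (Homo sapiens) for cytotoxicity (a lower number here means a stronger inhibitor, a higher number a weaker inhibitor), compound 1 `COc1ccc(S(=O)(=O)N2CCc3cccc(NC(=O)c4cccs4)c32)cc1` gives 31 nM and compound 3 `COc1ccc(S(=O)(=O)N2CCc3cccc(NC(=O)c4ccc(F)cc4)c32)cc1` gives 45 nM, so the two stand level, with a 1.5-fold higher number from compound 1 to compound 3 (0.16 log units; within the scatter). Compound 2 `COc1ccc(S(=O)(=O)N2CCc3cccc(NC(=O)Oc4ccccc4)c32)cc1` returns only a limit of the assay, > 10000 nM. The steps involving that limit are large: an at least 320-fold higher number from compound 1 to compound 2 (2.50 log units; beyond the scatter) and an at least 220-fold lower number from compound 2 to compound 3 (2.34 log units; beyond the scatter). Compound 4 `COc1ccc(S(=O)(=O)N2CCc3cccc(NC(=O)c4ccncc4)c32)cc1` differs from compound 3 by pyridin-4-yl in place of 4-fluorophenyl on a carbonyl carbon. An aromatic ring stays on the carbonyl carbon here, as it does in a 1.5-fold higher number from compound 1 to compound 3 (0.16 log units; within the scatter), and phenoxy, the group in an at least 220-fold lower number from compound 2 to compound 3 (2.34 log units; beyond the scatter), plays no part. No step beyond the scatter is therefore expected in this assay. The estimated step is a 1.5-fold lower number from compound 3 to compound 4 (0.18 log units; within the scatter). The expected value for compound 4 is 30 nM, with an estimated range of 8 nM to 200 nM.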

Compound 4, half-maximal inhibitory concentration: 8.8 nM
Estimate against measurement, compound 4: 3.4-fold (0.53 log units) above; the measured number falls inside the stated range.
By their numbers in this assay, from the lowest: compound 4; then compounds 1 and 3 (each within the scatter of the next). At a limit, above all of these: compound 2.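

At this place, on a carbonyl carbon whose other neighbour is an amide-type nitrogen, the earlier aromatic rings, thiophen-2-yl and 4-fluorophenyl, stood within the scatter of each other in this assay. Pyridin-4-yl separates from both, with a 5.1-fold lower number from compound 3 to compound 4 (0.71 log units; beyond the scatter) and a 3.5-fold lower number from compound 1 to compound 4 (0.55 log units; beyond the scatter), so the choice of aromatic ring does matter here. The contrast with phenoxy also widens, with an at least 1100-fold lower number from compound 2 to compound 4 (3.05 log units; beyond the scatter), though this step rests on a limit: the limit of > 10000 nM in this assay, at which 1 of the 4 values shown sits.

As far as these compounds go, what pyridin-3-yl or pyridin-2-yl would give on the same carbonyl carbon remains open. So does whether a 4-aminophenyl ring would behave like pyridin-4-yl or like 4-fluorophenyl.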